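The source may report more compounds than this note shows. Statements on the series, on what has been measured and on what is new or still open speak of the compounds shown alone.

Measured in a functional assay on B16 cells (Mus musculus) for antiproliferative activity, with a stated time of 72 h; on this read-out higher numbers stand for weaker inhibition and lower numbers for stronger inhibition:
- Compound 1 `OC[C@H]1O[C@@H](n2cnc3c(NCc4cccc(Br)c4)ncnc32)[C@H](O)[C@@H]1O`: > 166000 nM
- Compound 2 `OC[C@H]1O[C@@H](n2cnc3c(NCc4ccc(Br)cc4)ncnc32)[C@H](O)[C@@H]1O`: > 166000 nM
- Compound 3 `OC[C@H]1O[C@@H](n2cnc3c(NCc4ccc(Cl)cc4Cl)ncnc32)[C@H](O)[C@@H]1O`: > 166000 nM

Each entry is a limit, not a number. The set therefore offers only (the limit of > 166000 nM in this assay, at which 3 of the 3 values shown sit), and compound 3 has no position within it beyond that shared limit.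

Compound 4 `OC[C@H]1O[C@@H](n2cnc3c(NCc4ccc(Cl)c(Cl)c4)ncnc32)[C@H](O)[C@@H]1O` keeps the shared core and changes only the ring: 3,4-dichlorophenyl in place of 2,4-dichlorophenyl on a saturated chain carbon bound to a nitrogen on an aromatic ring.

The closest measured changes are a step that the two limits leave unreadable from compound 1 to compound 3, a step that the two limits leave unreadable from compound 2 to compound 3 and a step that the two limits leave unreadable from compound 1 to compound 2. None of them gives a size.

Compound 3 reads > 166000 nM, a limit, so no clear move in either direction is expected, and compound 4 will probably report a limit too.

The expected change is a number no higher from compound 3 to compound 4 (the limit leaves the size open), nothing beyond the scatter.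

For compound 4 the estimate is 166000 nM, with an expected range of 70000 nM to 250000 nM.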

Compound 4, half-maximal inhibitory concentration: > 166000 nM
Compound 4: a limit, no number; the forecaster's own chance of this, stated with the estimate: 80%; the middle value lies on the limit itself.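

Compound 4, like compound 1, compound 2 and compound 3, gives only a limit in this assay, so no step among them can be read: the limit of > 166000 nM in this assay, at which 4 of the 4 values shown sit.

Whether changing the ring shifts the antiproliferative activity of these compounds at all stays open.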